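The source may hold more compounds than are shown below. What is called first, only, known or untested is meant among the compounds shown, and "the series" means these compounds.

Measured in a physicochemical assay for solubility, read by HPLC, at pH 7.4; on this read-out lower numbers stand for lower solubility and higher numbers for higher solubility:
- compound 1 `CCCCCCCc1[nH]c2ccc([N+](=O)[O-])cc2c(=O)c1CO`: 5000 nM
- compound 2 `CCCCCCCc1[nH]c2ccc([N+](=O)[O-])cc2c(=O)c1C(=O)O`: 15000 nM
- compound 3 `CCCCCCCc1[nH]c2ccncc2c(=O)c1C(=O)OCC`: 50000 nM

Of these three, compound 3 has the highest number. Compound 2 is the nearest to it and compound 1 the furthest, and both gaps lie beyond the scatter. Compound 4 `CCCCCCCc1[nH]c2ccncc2c(=O)c1C(=O)O` differs from compound 3 by hydrogen in place of ethyl on an oxygen next to a carbonyl group, or ethoxycarbonyl to carboxy.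

Among the compounds with values here, no measured pair shows this exact change. The closest evidence is a 3.0-fold higher number from compound 1 to compound 2 (0.48 log units; beyond the scatter), a modest step with carboxy in place of hydroxymethyl on an aromatic carbon. That step starts from a different group on a different core, so it offers only weak guidance. Compound 2 also carries carboxy, yet its 15000 nM is lower than the number for compound 3, though the two cores differ. A small rise in this assay is therefore expected, possibly none beyond the scatter. The expected change is a 1.4-fold higher number from compound 3 to compound 4 (0.15 log units; within the scatter). The estimate for compound 4 is 70000 nM, with an expected range of 25000 nM to 200000 nM.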

Compound 4, solubility: 50000 nM
Estimate against measurement, compound 4: 1.4-fold (0.15 log units) above, within the range that was stated.
By their numbers in this assay, from the lowest: compound 1; then compound 2; then compounds 3 and 4 (each within the scatter of the next).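

In this assay, hydrogen in place of ethyl on an oxygen next to a carbonyl group gives no change at the digits printed from compound 3 to compound 4 (within the scatter). Within the data shown here, this is the first direct reading of ethoxycarbonyl to carboxy, and on this core the read-out does not separate the two groups. The earlier step, a 3.0-fold higher number from compound 1 to compound 2 (0.48 log units; beyond the scatter), showed carboxy entering in place of hydroxymethyl on the core of compound 1, so it could not show what removing ethyl from this oxygen does. Nothing measured here accounts for the absence of a change.

From the compounds shown here alone, it remains open whether ethoxycarbonyl to carboxy would read the same on the core of compound 2. Also open, going by these compounds, is how methyl or propyl on this oxygen, or a primary amide in place of carboxy, would read in this assay.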